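The source may report more compounds than this note shows. Statements on the series, on what has been measured and on what is new or still open speak of the compounds shown alone.

Within the data shown here, compound 3 `CC(C)(N)CC(=O)N[C@@H]1CCc2ccccc2N(Cc2ccc(-c3cccnc3-c3nn[nH]n3)cc2)C1=O` is one of three compounds measured in a functional assay (Pituitary gland cell) with Rattus norvegicus as the target; a lower number here means that less compound is needed, a higher number that more compound is needed for the effect. In this assay compound 3 gives 2350 nM. Compound 1 `CC(C)(N)CC(=O)N[C@@H]1CCc2ccccc2N(Cc2ccc(-c3ccccc3C(=O)O)cc2)C1=O` gives 2500 nM, and the step of a 1.1-fold lower number from compound 1 to compound 3 (0.03 log units; within the scatter) keeps the two within the scatter of each other. Compound 2 `Cn1ncnc1-c1ccccc1-c1ccc(CN2C(=O)[C@H](NC(=O)CC(C)(C)N)CCc3ccccc32)cc1` gives 265 nM, the lowest number of the three, and the step of an 8.9-fold higher number from compound 2 to compound 3 (0.95 log units; beyond the scatter) sets it clearly apart. Compound 3 therefore stands second highest, close to compound 1 and well separated from compound 2.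

Compound 4 `CC(C)(N)CC(=O)N[C@@H]1CCc2ccccc2N(Cc2ccc(-c3sccc3-c3nn[nH]n3)cc2)C1=O` has not yet been measured. It differs from compound 3 in one place: 3-(2H-tetrazol-5-yl)thiophen-2-yl in place of 2-(2H-tetrazol-5-yl)pyridin-3-yl on an aromatic carbon. The tetrazole is kept; only the ring that carries it is exchanged for a different one.

Among the measured compounds shown here, no measured step changes this ring while keeping the tetrazole, so no step bears on it directly. The closest comparison is a 1.1-fold lower number from compound 1 to compound 3 (0.03 log units; within the scatter), where a larger exchange of the whole group left the number essentially unchanged. The steps of a 9.4-fold lower number from compound 1 to compound 2 (0.97 log units; beyond the scatter) and an 8.9-fold higher number from compound 2 to compound 3 (0.95 log units; beyond the scatter) concern a different group and offer no guide here. For the measured compounds named here, with no precedent for this kind of ring swap, a step within the scatter is expected, in either direction.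

For compound 4 a value of 2000 nM is expected, with a range from 700 nM to 6000 nM, which corresponds to an expected step of a 1.2-fold lower number from compound 3 to compound 4 (0.07 log units; within the scatter).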

Compound 4, half-maximal effective concentration: 140 nM
Compound 4: the middle estimate sits 14-fold (1.15 log units) above what was measured; the whole stated range lies above it.
By their numbers in this assay, from the lowest: compounds 4 and 2 (each within the scatter of the next); then compounds 3 and 1 (each within the scatter of the next).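

In this assay, the ring that carries the tetrazole turns out to matter greatly: with the tetrazole kept, the exchange of 2-(2H-tetrazol-5-yl)pyridin-3-yl for 3-(2H-tetrazol-5-yl)thiophen-2-yl gives a 17-fold lower number from compound 3 to compound 4 (1.22 log units; beyond the scatter), so the tetrazole alone does not set the number at this place. The thiophene group also gives an 18-fold lower number from compound 1 to compound 4 (1.25 log units; beyond the scatter), while a 1.9-fold lower number from compound 2 to compound 4 (0.28 log units; within the scatter) stays within the scatter, so two quite different groups, one with a tetrazole on a thiophene and one with a methyl triazole on a phenyl ring, reach the same level on this core. No measurement shown here accounts for the effect of the ring exchange.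

On these data alone, it remains open whether the lower number goes with the sulfur atom, with the five-membered ring, or with the absence of the pyridine nitrogen, and a tetrazole on a plain phenyl ring or on a furan ring would help to separate these. Also open, as far as these compounds go, is whether the thiophene ring gives the same result when it carries a carboxylic acid or a 1-methyl-1H-1,2,4-triazol-5-yl group instead of the tetrazole.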